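Swapping Ethoxy for Dimethylamino in Compound 2

The source may report more compounds than this note shows. Statements on the series, on what has been measured and on what is new or still open speak of the compounds shown alone.

In a functional assay on HaCaT cells (Homo sapiens) for antiproliferative activity, read by sulforhodamine B assay, with a stated time of 3 days (a lower number here means a stronger inhibitor, a higher number a weaker inhibitor), compound 2 `CCOc1ccc(OC)c(CCc2ccc(O)c(C(=O)OC)c2)c1` gives 540 nM. Compound 3 `CCOc1ccc(OCC)c(CCc2ccc(O)c(C(=O)OC)c2)c1` gives 380 nM, within the scatter of compound 2, so these two share the stronger end of this small set. Compound 1 `COC(=O)c1cc(CCc2cccc(OC)c2OC)ccc1O`, at 33000 nM, is far weaker.

Compound 4 `COC(=O)c1cc(CCc2cc(N(C)C)ccc2OC)ccc1O` has not yet been measured. It is compound 2 with one change, dimethylamino in place of ethoxy on an aromatic carbon.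

For the measured compounds named here, only one measured step is available, and it bears on this change only loosely: a 1.4-fold lower number from compound 2 to compound 3 (0.15 log units; within the scatter). Going by the values given here, that step adds a methyl in place of hydrogen on a saturated chain carbon, but it leaves the ethoxy of compound 2 untouched and brings in no dimethylamino, so this swap has no direct precedent here. With compound 1 at 33000 nM showing how high numbers in this set can go, a wide range is warranted. The expected change is modest but uncertain: a 1.9-fold higher number from compound 2 to compound 4 (0.27 log units; within the scatter). For compound 4 the estimated value is 1000 nM, with an expected range from 200 nM to 6000 nM.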

Compound 4, half-maximal inhibitory concentration: 920 nM
Compound 4: the middle estimate sits 1.1-fold (0.04 log units) above what was measured; measured number inside the range.
By their numbers in this assay, from the lowest: compounds 3, 2 and 4 (each within the scatter of the next, the first and the last beyond it); then compound 1.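

In this assay the swap gives a 1.7-fold higher number from compound 2 to compound 4 (0.23 log units; within the scatter), so on this aromatic carbon, meta to a large group and para to a methoxy group, dimethylamino can take the place of ethoxy without the number leaving the usual scatter. This is the first change shown at this position, and it puts nitrogen where oxygen stood while both groups keep 3 heavy atoms and 1 hydrogen-bond acceptor. No measurement shown here offers a reason for this outcome.

On these data alone, whether an unsubstituted amino group or a longer chain such as butoxy on this carbon would also stay within the scatter of compound 2 remains open. So does whether dimethylamino would behave the same way alongside the second ethoxy of compound 3.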